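One Ring Swap, Carried Over to a Second Core

A few compounds are considered here, and "the series" means these few. Any claim that something is new, unique, unknown or untested is made for them only; others in the source may bear on it.

Of the compounds shown here, three have been measured in a functional assay on SiHa cells (Homo sapiens) for inhibition, read by sulforhodamine B assay; a lower number here means a stronger inhibitor of growth, a higher number a weaker inhibitor of growth. Compound 1 `Cc1ccc2[nH]c(-c3ccc(-c4ccc(-c5ccc(N(C)C)cc5)cc4)cc3)nc2c1` gives 7110 nM. Compound 2 `Cc1ccc2[nH]c(-c3ccc(-c4ccc(-c5cccc(Cl)c5)cc4)cc3)nc2c1` gives 3600 nM. Compound 3 `CN(C)c1ccc(-c2ccc(-c3ccc(-c4nc5c(O)cccc5[nH]4)cc3)cc2)cc1` gives 6240 nM. Two single changes connect these three. From compound 1 to compound 2 the change is 3-chlorophenyl in place of 4-(dimethylamino)phenyl on an aromatic carbon, and it made a step of a 2.0-fold lower number from compound 1 to compound 2 (0.30 log units; within the scatter), a step that stays inside the usual scatter of repeated measurements. From compound 1 to compound 3 the two cores differ by 4-hydroxy-1H-benzimidazol-2-yl in place of 5-methyl-1H-benzimidazol-2-yl on an aromatic carbon, and that gave a 1.1-fold lower number from compound 1 to compound 3 (0.06 log units; within the scatter), again inside the scatter. So among the measured compounds none can be called stronger or weaker than another in this assay.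

Compound 4 `Oc1cccc2[nH]c(-c3ccc(-c4ccc(-c5cccc(Cl)c5)cc4)cc3)nc12` has not been measured. Among the compounds with values here, it differs from compound 3 by 3-chlorophenyl in place of 4-(dimethylamino)phenyl on an aromatic carbon, which is the same change as the one from compound 1 to compound 2: the group that leaves, the group that enters and the place on the ring are the same in both pairs. The only thing that sets the two pairs apart is the core, and that difference in cores, from compound 1 to compound 3, moved the number by no more than the scatter.

Within the data shown here, on that basis the step onto the second core in this assay is expected to resemble the one from compound 1 to compound 2. The expected step is about a 2.0-fold lower number from compound 3 to compound 4 (0.30 log units; within the scatter), and since it rests on a single earlier pair it remains an expectation only. Compound 4 is therefore estimated at 3100 nM, most likely between 1500 nM and 6500 nM.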

Compound 4, concentration for 50% growth inhibition: 8400 nM
For compound 4 the middle estimate is 2.7-fold (0.43 log units) below the measured one, outside the stated range (above it).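

In this assay, putting 3-chlorophenyl in place of 4-(dimethylamino)phenyl on the core of compound 3 gave a 1.3-fold higher number from compound 3 to compound 4 (0.13 log units; within the scatter), a step that stays inside the usual scatter, just as the same change did on the core of compound 1. Within the data shown here, the numbers seem to point in opposite directions on the two cores, but that is no sign that the core alters what this change does, since the two steps cannot be told apart: the same change on two cores in this assay, a 2.0-fold lower number (0.30 log units; within the scatter) from compound 1 to compound 2 and a 1.3-fold higher number (0.13 log units; within the scatter) from compound 3 to compound 4, 2.7-fold (0.42 log units) apart, within the scatter of two such steps With every step in this small set inside the scatter, there is no clear effect to carry from one core to the other, so the result shows only that the swap made no readable difference on either core, and it neither proves nor disproves that a real effect would transfer between them.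

The compounds shown leave open whether a carboxylic acid or a longer chain at that same place, in place of 3-chlorophenyl, would move the number beyond the scatter on either core. They also leave open whether a methoxy group in place of the methyl or the hydroxy on the core would do so.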